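The source may hold more compounds than are shown below. What is called first, only, known or untested is meant among the compounds shown, and "the series" means these compounds.

Measured in a functional assay on A549 cells (Homo sapiens) for antiproliferative activity, read by sulforhodamine B assay, with a stated time of 48 h; on this read-out lower numbers stand for stronger inhibition and higher numbers for weaker inhibition: compound 1 `COc1cc(OC)c2sc(-c3ccc(N/C=C\C(=O)c4cc(OC)c(OC)c(OC)c4)cc3)nc2c1` gives 21800 nM; compound 2 `COc1cc(OC)c2sc(-c3ccc(N/C=C\C(=O)c4ccc(OC)c(O)c4)cc3)nc2c1` gives 10600 nM; compound 3 `COc1cc(OC)c2sc(-c3ccc(N/C=C\C(=O)c4cc(OC)c(OC)c(OC)c4Br)cc3)nc2c1` gives 12000 nM.

Compound 1 has the highest number of the three, meaning the weakest inhibition. Compound 4 `COc1cc(OC)c2sc(-c3ccc(N/C=C\C(=O)c4cc(OC)c(OC)c([N+](=O)[O-])c4)cc3)nc2c1` differs from it in one place: nitro in place of methoxy on an aromatic carbon. Two measured steps start from compound 1 and both lower the number. a 2.1-fold lower number from compound 1 to compound 2 (0.31 log units; beyond the scatter), though that change reworks the whole phenyl ring. a 1.8-fold lower number from compound 1 to compound 3 (0.26 log units; within the scatter), a single added group on the same ring as the present change. Neither step is the nitro-for-methoxy swap itself, so only a small move is expected, if any, probably downward. Compound 4 is therefore estimated at 15000 nM, with a range from 6000 nM to 40000 nM. The expected step is a 1.5-fold lower number from compound 1 to compound 4 (0.16 log units; within the scatter).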

Compound 4, half-maximal inhibitory concentration: 13000 nM
Estimate against measurement, compound 4: 1.2-fold (0.06 log units) above, within the range that was stated.
By their numbers in this assay, from the lowest: compounds 2, 3, 4 and 1 (each within the scatter of the next, the first and the last beyond it).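

In this assay, the first change shown at this position, with nitro in place of methoxy, gives a 1.7-fold lower number from compound 1 to compound 4 (0.22 log units; within the scatter). The methoxy group on this aromatic carbon can therefore be exchanged for nitro without a shift beyond the usual scatter, and the number stays in the same range as for the other compounds. No measurement shown gives a reason for this result. Still open, on these data alone, is whether an amine or a carboxylic acid on this carbon would shift the number further, and whether any group here can bring a much lower number.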